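Taking the hydroxy group off compound 3

A few compounds are considered here, and "the series" means these few. Any claim that something is new, unique, unknown or untested is made for them only; others in the source may bear on it.

- compound 1 `COc1cc2c(cc1C)NC(=O)/C2=C/c1c(OC)nc2sc(C)cn12` gives 4570 nM
- compound 2 `COc1ccc2c(c1)/C(=C\c1c(OC)nc3sc(C)cn13)C(=O)N2` gives 870 nM
- compound 3 `COc1nc2sc(C)cn2c1/C=C1/C(=O)Nc2ccc(O)cc21` gives 4570 nM

In a functional assay on cells (Breast carcinoma cell, Homo sapiens) for cytotoxicity, read by sulforhodamine B assay, with a stated time of 48 h (on this read-out higher numbers stand for weaker inhibition of growth and lower numbers for stronger inhibition of growth), compound 3 gives 4570 nM and shares the highest number of the three with compound 1, while compound 2 sits lowest. The next structure is compound 4 `COc1nc2sc(C)cn2c1/C=C1/C(=O)Nc2ccccc21`, which carries hydrogen in place of hydroxy on an aromatic carbon and is otherwise the same.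

Among the compounds with values here, two measured steps bear on this change. The closer one is a 5.3-fold higher number from compound 2 to compound 3 (0.72 log units; beyond the scatter) where hydrogen took the place of methyl on an oxygen on an aromatic ring. The other is a 5.3-fold lower number from compound 1 to compound 2 (0.72 log units; beyond the scatter) where hydrogen took the place of methyl on an aromatic carbon, so there the loss of a group lowered the number. Neither step removes a hydroxy group, which makes them a loose guide. A lower number is expected, though a smaller shift than those two steps. The expected shift is a 2.5-fold lower number from compound 3 to compound 4 (0.40 log units; beyond the scatter) in this assay on this estimate. Compound 4 is estimated at 1800 nM with an expected range from 600 nM to 5000 nM in this read-out.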

Compound 4, concentration for 50% growth inhibition: 2520 nM
The estimate for compound 4 lay 1.4-fold (0.15 log units) below the measured number, and the stated range covers the measured number.
By their numbers in this assay, from the lowest: compound 2; then compounds 4, 1 and 3 (each within the scatter of the next).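

In this assay the step of a 1.8-fold lower number from compound 3 to compound 4 (0.26 log units; within the scatter) shows that a hydroxy group and a plain hydrogen cannot be told apart at this place on the six-membered aromatic ring. The step of a 2.9-fold higher number from compound 2 to compound 4 (0.46 log units; beyond the scatter) tells a different story for methoxy at the same place, so among these three groups methoxy alone stands apart from the others, with compound 2 giving the lowest number of the set. No measured data here explain why the methoxy compound differs while the hydroxy group makes no clear difference. From the compounds shown here alone, what stays open is whether this gain belongs to methoxy in particular or would also appear with a longer ether such as ethoxy, or with a different atom or group such as fluorine or an amine. Going by these compounds, it is also open whether the same order would hold in other cell types.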